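Iodo in Place of Vinyl on a Shared Core

This account rests on a few compounds, and the source may have more. Where it says the series, first, only, none or still open, it means among the compounds named here.

Of the compounds shown here, two have been measured in a functional assay on CHO cells for antagonist activity at Orexin/Hypocretin receptor type 1 (Homo sapiens), read by FLIPR and calcium flux; on this read-out higher numbers stand for weaker inhibition and lower numbers for stronger inhibition. Compound 1, `CNC(=O)[C@@H](c1ccccc1)N1CCn2c(COC)nc(Cl)c2[C@@H]1CCc1ccc(C(F)(F)F)cc1`, gives 1650 nM. Compound 2, `C=Cc1nc(CC)n2c1C(CCc1ccc(C(F)(F)F)cc1)N([C@@H](C(=O)NC)c1ccccc1)CC2`, gives 150 nM. Compound 2 thus stands at the lower, stronger end of these two numbers, and its gap to compound 1 lies beyond the scatter. The two compounds differ in more than one place, however, so no single structural step can be read from them.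

Compound 3, `CCc1nc(I)c2n1CCN([C@@H](C(=O)NC)c1ccccc1)C2CCc1ccc(C(F)(F)F)cc1`, has not yet been measured. Compared with compound 2 it shows (iodo in place of vinyl on an aromatic carbon). Among the compounds with values here, no measured pair isolates this change. Compound 1 also carries a halogen at that place of the shared core and gives the weaker of the two known values, but it differs from compound 2 elsewhere as well, so that comparison guides the guess only loosely.

Compound 3 is expected to give about 300 nM, within a range from 100 nM to 1000 nM. This amounts to an expected step of a 2.0-fold higher number from compound 2 to compound 3 (0.30 log units; within the scatter) toward weaker inhibition, a modest shift that may well stay within the scatter.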

Compound 3, half-maximal inhibitory concentration: 717 nM
Compound 3: the middle estimate sits 2.4-fold (0.38 log units) below what was measured; measured number inside the range.
By their numbers in this assay, from the lowest: compound 2; then compound 3; then compound 1.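

In this assay, within the data shown here, the swap of vinyl for iodo on this aromatic carbon gives a 4.8-fold higher number from compound 2 to compound 3 (0.68 log units; beyond the scatter), the first change in a single place that can be read on the shared core. It shows that this carbon, next to the ring nitrogen, is not indifferent to the group it carries. Replacing the two carbons of vinyl with one iodine atom weakens inhibition by a step beyond the scatter of repeat measurements, although compound 3 keeps a measurable value of 717 nM. Nothing shown here accounts for the size or direction of this step.

Among these compounds, whether vinyl itself matters, or whether other groups on this carbon, such as a nitrile, a bromo or a longer chain like propyl, would match or beat it, stays open with only two groups compared directly. Chloro stands at this place in compound 1, but that compound also differs from compound 2 and compound 3 elsewhere on the core, so what chloro does here cannot be separated from those other differences.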